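Swapping the basic ring on the aryl ether side chain

A few compounds are considered here, and "the series" means these few. Any claim that something is new, unique, unknown or untested is made for them only; others in the source may bear on it.

Within the data shown here, compound 2 `CN1CCC(COc2ccc(S(=O)(=O)NC(=O)c3ccc(N4CCN(CC5=C(c6ccc(C(F)(F)F)cc6)CC(C)(C)CC5)CC4)cc3Oc3cnc4[nH]ccc4c3)cc2[N+](=O)[O-])C1` gives 0.75 nM in an assay on isolated protein for displacement of a labelled ligand from Apoptosis regulator Bcl-2 (Homo sapiens), with a stated time of 15 min (a lower number here means a stronger inhibitor, a higher number a weaker inhibitor), the lowest of the two numbers recorded, with compound 1 `CC1(C)CCC(CN2CCN(c3ccc(C(=O)NS(=O)(=O)c4ccc(OCC5CCOCC5)c([N+](=O)[O-])c4)c(Oc4cnc5[nH]ccc5c4)c3)CC2)=C(c2ccc(C(F)(F)F)cc2)C1` as its only neighbour at 1 nM in this assay; the two lie within the scatter of each other. Compound 3 `CCN1CCC(COc2ccc(S(=O)(=O)NC(=O)c3ccc(N4CCN(CC5=C(c6ccc(C(F)(F)F)cc6)CC(C)(C)CC5)CC4)cc3Oc3cnc4[nH]ccc4c3)cc2[N+](=O)[O-])CC1` differs from compound 2 in one place: 1-ethylpiperidin-4-yl in place of 1-methylpyrrolidin-3-yl on a saturated chain carbon bound to an oxygen on an aromatic ring. Among the measured compounds shown here, the one measured step that bears on this position is a 1.3-fold lower number from compound 1 to compound 2 (0.12 log units; within the scatter), a change of saturated ring at the same place that left the number essentially where it was. Compound 3 is therefore expected to show no step beyond the scatter, with the estimated change being a 1.2-fold higher number from compound 2 to compound 3 (0.08 log units; within the scatter). On that basis compound 3 is estimated at 0.9 nM in this assay, with a range from 0.4 nM to 2.5 nM.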

Compound 3, half-maximal inhibitory concentration: 0.5 nM
Beside the measured number, compound 3's estimate is 1.8-fold (0.26 log units) above it; the range from low to high includes it.
By their numbers in this assay, from the lowest: compounds 3, 2 and 1 (each within the scatter of the next).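

In this assay the position also accepts a six-membered ring carrying an ethyl group on its nitrogen: 1-ethylpiperidin-4-yl in place of 1-methylpyrrolidin-3-yl gives (a 1.5-fold lower number from compound 2 to compound 3 (0.18 log units; within the scatter)), and in place of oxan-4-yl it gives (a 2.0-fold lower number from compound 1 to compound 3 (0.30 log units; within the scatter)). The earlier pair had shown this for only two rings, whereas three saturated rings of differing size and ring hetero atom now sit within the scatter of one another at this saturated chain carbon. No measurement given here explains why the number stays so level across these changes.

All three groups are saturated rings, so an open-chain amine, a carboxylic acid or a plain methoxy at this place remains an open case. Also open, on these data alone, is whether a longer chain between the oxygen and the ring would leave the number as level.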